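Replacing the Furanyl Ketone of Compound 1 with a Thioamide

A few compounds are considered here, and "the series" means these few. Any claim that something is new, unique, unknown or untested is made for them only; others in the source may bear on it.

The study examines a series built on a shared core, tested in a functional assay (aorta) with Rattus norvegicus as the target; a lower number here means a less potent compound, a higher number a more potent compound, by a factor of ten per unit of this negative logarithm. Compound 1 `CC1(C)C=C(n2ccccc2=O)c2cc(C(=O)c3ccco3)ccc2O1` gives 6.49 in this assay, the highest of the three measured numbers. The two carbamates sit well below it: compound 2 `CC1(C)C=C(n2ccccc2=O)c2cc(OC(=O)Nc3ccccc3F)ccc2O1` gives 5.38, a number under compound 1 by a margin beyond the scatter, and compound 3 `CC1(C)C=C(n2ccccc2=O)c2cc(OC(=O)Nc3ccc(C(F)(F)F)cc3)ccc2O1` gives 5.1, the furthest from compound 1. Going by the values given here, the only step between measured compounds that differ in one place is a number 0.28 log units lower from compound 2 to compound 3 (within the scatter), a swap of one aryl group for another on an amide-type nitrogen that does not reach beyond the scatter.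

Compound 4 `CC1(C)C=C(n2ccccc2=O)c2cc(C(=N)S)ccc2O1` is not yet measured. It differs from compound 1 as follows: a group of 3 heavy atoms (1 carbon, 1 nitrogen, 1 sulfur; no ring) in place of a group of 7 heavy atoms (5 carbon, 2 oxygen; one five-membered aromatic ring with 1 hetero atom), on an aromatic carbon. Among the compounds with values here, no measured pair exchanges a group on this aromatic carbon for something of a different size or ring count, so the carbamate step carries no direct information about this change; it shows only that a change at a different position moved the number little. The loss of the five-membered aromatic ring is a larger structural change than anything measured here. Compound 4 is expected to give 5.6, with a range from 4.8 to 6.4, which amounts to an expected step of a number 0.89 log units lower from compound 1 to compound 4 (beyond the scatter), a decrease, estimated mainly because compound 1 stands at 6.49 and the measured carbamates fall well below it.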

Compound 4, logarithm of the reciprocal of the active concentration, log(1/C): 6.21
Compound 4: middle estimate off by 0.61 log units, on the low side; low and high end bracket the measured number.
By their numbers in this assay, from the lowest: compounds 3 and 2 (each within the scatter of the next); then compounds 4 and 1 (each within the scatter of the next).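

In this assay, the change on this aromatic carbon gives a number 0.28 log units lower from compound 1 to compound 4 (within the scatter), the first step measured at this position, and it shows that compound 1 and compound 4 cannot be told apart despite the large difference between the two groups. For this pair, the (furan-2-yl)carbonyl group and its five-membered aromatic ring are therefore not required to keep the number at this level: a group with no ring and 3 heavy atoms serves as well, even though it brings 2 hydrogen-bond donors where the group it replaces has 0. Nothing available accounts for why the two groups give numbers so close together.

The compounds shown leave open which atoms of the entering group matter, as they include no primary amide, with oxygen in place of the sulfur, and no nitrile on this aromatic carbon. They also leave open how far this tolerance extends, since a single pair cannot say how a carboxylic acid, an amine or a longer chain would read at the same position.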